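This account rests on a few compounds, and the source may have more. Where it says the series, first, only, none or still open, it means among the compounds named here.

Working notes on the series: in an ADME assay on the whole organism for pharmacokinetics, with Rattus norvegicus as the target, at a dose of 2 mg/kg by the intravenous route (a lower number here means slower removal, a higher number faster removal of the compound), compound 2 `CO[C@H]1CC[C@H](N2C(=O)CNc3ncc(-c4ccc(-c5nc[nH]n5)nc4C)nc32)CC1` gives 16 mL/min/kg, the only number available so far. Compound 1 `Cc1nc(-c2nc[nH]n2)ccc1-c1cnc2c(n1)N(CC1CCOCC1)C(=O)CN2` stands as "not determined" (no result reported), so compound 2 cannot yet be ranked against another compound, and no trend can be read from the series.

The next compound to be measured is compound 3 `Cc1nc(-c2nc[nH]n2)ccc1-c1cnc2c(n1)N(CCC1CCOCC1)C(=O)CN2`. Its structural change from compound 2 is 2-(oxan-4-yl)ethyl in place of 4-methoxycyclohexyl on an amide-type nitrogen in a ring. The shared core and the rest of the molecule stay the same.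

For the measured compounds named here, no pair of measured compounds differing in one place is available in this assay, so the size of this step has no direct precedent. Going by the values given here, the only anchor is compound 2 at 16 mL/min/kg, and the expectation carries wide uncertainty. A modest rise is expected, with no fall foreseen, and the expected change is a 1.6-fold higher number from compound 2 to compound 3 (0.21 log units; within the scatter). For compound 3 the estimated clearance is 26 mL/min/kg, with an expected range of 11 mL/min/kg to 55 mL/min/kg.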

Compound 3, clearance: 37.9 mL/min/kg
Compound 3: middle estimate off by 1.5-fold (0.16 log units), on the low side; low and high end bracket the measured number.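

In this assay, for the compounds shown here, the change on the amide-type nitrogen in a ring gives the first readable step at this position, a 2.4-fold higher number from compound 2 to compound 3 (0.37 log units; beyond the scatter), with the shared core and the rest of the molecule unchanged. The 4-methoxycyclohexyl and 2-(oxan-4-yl)ethyl groups have the same heavy-atom composition and the same hydrogen-bond donor and acceptor counts, so the readout at this position is sensitive to how these atoms are joined, not only to which atoms are present. The step changes the ring, the link to the nitrogen and the 2 defined stereocentres together, and no measurement at hand accounts for it or assigns it to any one of these features.

As far as these compounds go, compound 1, which carries an oxan-4-yl group on a shorter chain, has no result, so its steps to compound 2 and compound 3 cannot be read, and the effect of chain length on this ring remains unknown. From the compounds shown here alone, it also remains open whether a longer chain, or a piperidine ring in place of the oxan-4-yl ring, would move clearance further in the same direction or reverse it.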